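Cytotoxicity notes: from compound 1 to compound 4

This account rests on a few compounds, and the source may have more. Where it says the series, first, only, none or still open, it means among the compounds named here.

Compound 1 `COc1ccc(/C=C/C(=O)c2ccc(OC)c3c2OC(C)(C)C=C3)cc1OCCO` is tested in an ADME assay on L02 cells (Homo sapiens) for cytotoxicity, read by MTT assay; on this read-out lower numbers stand for stronger inhibition and higher numbers for weaker inhibition. In this assay compound 1 gives > 10000 nM, a limit of the assay rather than a number. Compound 2 `CCC(=O)Oc1cc(/C=C/C(=O)c2ccc(OC)c3c2OC(C)(C)C=C3)ccc1OC` gives > 10000 nM in this assay, again only a limit. Compound 3 `COc1ccc(/C=C/C(=O)c2ccc(OC)c3c2OC(C)(C)C=C3)cc1OC(=O)C1CC1` gives > 10000 nM in this assay, also a limit. Because of the limit of > 10000 nM in this assay, at which 3 of the 3 values shown sit, the steps a step that the two limits leave unreadable from compound 1 to compound 2, a step that the two limits leave unreadable from compound 1 to compound 3 and a step that the two limits leave unreadable from compound 2 to compound 3 stay unreadable in size, so compound 1 stands at the limit and nowhere on a number scale. Compound 4 `COc1ccc(/C=C/C(=O)c2ccc(OC)c3c2OC(C)(C)C=C3)cc1CS(C)(=O)=O` differs from compound 1 by (methylsulfonyl)methyl in place of 2-hydroxyethoxy on an aromatic carbon. Among the measured compounds shown here, no measured step touches the 2-hydroxyethoxy group, so the expectation rests on the shared limit alone. Compound 4 is therefore expected to give about 15000 nM in this assay, within 5000 nM to 50000 nM, an expected step that the limit leaves unreadable from compound 1 to compound 4, most likely again reported only as a limit.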

Compound 4, half-maximal inhibitory concentration: > 10000 nM
Compound 4: a limit, no number (the forecaster's own chance of this, stated with the estimate: 80%); the middle value does not contradict the limit.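

Among the compounds shown here, no step from compound 1, compound 2 or compound 3 to compound 4 can be read in size, because all four compounds rest on one limit: the limit of > 10000 nM in this assay, at which 4 of the 4 values shown sit.

The compounds shown leave open whether these exchanged groups differ in cytotoxicity at all.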